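The source may report more compounds than this note shows. Statements on the series, on what has been measured and on what is new or still open speak of the compounds shown alone.

Measured so far:
compound 1 `O=C(CSc1cccc(O)c1)Nc1ccc2nc(NC(=O)c3cc(Cl)cc(Cl)c3)sc2c1` — 5440 nM
compound 2 `Cc1cc(C)cc(C(=O)Nc2nc3ccc(NC(=O)CSc4ccc(Cl)cc4)cc3s2)c1` — 65100 nM
compound 3 `Oc1ccc(Cl)cc1/C=N/c1ccc(-c2nc3ccccc3o2)c(O)c1` — 20100 nM

All three numbers come from a functional assay on HCT-116 cells (Homo sapiens) for antiproliferative activity, read by MTT assay, with a stated time of 72 h; a higher number here means a weaker inhibitor, a lower number a stronger inhibitor. Compound 1 gives the lowest number of the three; compound 3 stands nearest to it and compound 2 furthest, and both gaps lie beyond the usual scatter. Compound 4 `O=C(CSc1cccc(O)c1)Nc1ccc2nc(NC(=O)c3cccs3)sc2c1` has not yet been measured in this assay. Against compound 1 the change is thiophen-2-yl in place of 3,5-dichlorophenyl on a carbonyl carbon. Going by the values given here, no step between measured compounds covers this change, so the expectation rests on compound 1 alone, at 5440 nM. The expected step is a 2.8-fold higher number from compound 1 to compound 4 (0.44 log units; beyond the scatter), toward a weaker inhibitor and beyond the scatter. Compound 4 is estimated at 15000 nM, with a range from 5000 nM to 45000 nM.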

Compound 4, half-maximal inhibitory concentration: 7020 nM
For compound 4 the middle estimate is 2.1-fold (0.33 log units) above the measured one; low and high end bracket the measured number.
By their numbers in this assay, from the lowest: compounds 1 and 4 (each within the scatter of the next); then compound 3; then compound 2.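

Thiophen-2-yl in place of 3,5-dichlorophenyl on a carbonyl carbon gives a 1.3-fold higher number from compound 1 to compound 4 (0.11 log units; within the scatter) in this assay and leaves the two compounds level. This position therefore accepts a five-membered aromatic ring with a sulfur atom, and in this pair the two chlorine atoms are not needed to hold the level of compound 1. No measured property accompanies this pair to account for the result.

Still open, as far as these compounds go, is whether a non-aromatic group on this carbonyl carbon, such as a cyclohexyl ring or a short chain carrying an amine, holds the same level. From the compounds shown here alone, a carboxylic acid on the thiophene ring is equally open.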